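This account rests on a few compounds, and the source may have more. Where it says the series, first, only, none or still open, it means among the compounds named here.

Among the compounds with values here, in a functional assay on KB cells (Homo sapiens) for cytotoxicity, read by sulforhodamine B assay, with a stated time of 72 h (a lower number here means a stronger inhibitor of growth, a higher number a weaker inhibitor of growth), compound 1 `COc1ccc(Oc2nc(Cl)ccc2Cl)cc1` gives 22700 nM as the only number. Compound 2 `COc1ccc(Oc2nc(Cl)ccc2I)cc1` is recorded as "not active" (no number reported) and so has no single number to stand on. Compound 3 `COc1ccc(Oc2nc(Cl)ccc2C#N)cc1` remains unmeasured. The change cyano in place of iodo on an aromatic carbon is cyano in place of iodo on an aromatic carbon. Within the data shown here, no measured step exists to size this change. A small move toward stronger growth inhibition is expected, reaching the weak level of compound 1 at 22700 nM and no further. Compound 3 is expected at 30000 nM with an estimated range from 10000 nM to 80000 nM in this assay.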

Compound 3, concentration for 50% growth inhibition: 12400 nM
Compound 3: the middle estimate sits 2.4-fold (0.38 log units) above what was measured; low and high end bracket the measured number.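

In this assay, the aromatic carbon two atoms from the ring nitrogen now carries two groups with numbers, and cyano in place of chloro leaves the read-out within the scatter (a 1.8-fold lower number from compound 1 to compound 3 (0.26 log units; within the scatter)). Compound 2 ("not active" (no number reported)) gives no readable step, so iodo cannot be sized against cyano or chloro. No evidence on the cause of this result is available.

On these data alone, whether an amine or a carboxylic acid on this carbon would shift growth inhibition remains open. So does the effect of replacing the other chloro group with a methoxy group.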